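Two limits and one untested swap

A few compounds are considered here, and "the series" means these few. Any claim that something is new, unique, unknown or untested is made for them only; others in the source may bear on it.

Measured in a functional assay on K562 cells (Homo sapiens) for antiproliferative activity, read by MTT assay, with a stated time of 48 h; a higher number here means a weaker inhibitor, a lower number a stronger inhibitor:
Compound 1 `O=C1Nc2ccc(-c3ccc(C(F)(F)F)cc3)cc2C1=O`: > 10000 nM
Compound 2 `COc1ccc(-c2ccc3c(c2)C(=O)C(=O)N3c2ccc(OC)cc2)cc1`: > 10000 nM

Compound 2 gives > 10000 nM, which is a limit of the assay and not a number. Compound 1 also gives only a limit, > 10000 nM. Among the measured compounds shown here, no measured pair therefore shows how large a step can be in this assay.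

Compound 3 `COc1ccc(-c2ccc3c(c2)C(=O)C(=O)N3Cc2ccc(C)cc2)cc1` has 4-methylbenzyl in place of 4-methoxyphenyl on an amide-type nitrogen in a ring. Compound 3 keeps the rest of compound 2 unchanged.

A clear step towards a stronger inhibitor is expected, but this is a tentative call that rests only on the limit of compound 2, > 10000 nM. The estimated step of an at least 12-fold lower number from compound 2 to compound 3 (1.09 log units; beyond the scatter) is uncertain in size. For compound 3 the expected value is 800 nM. The estimated range for this compound runs from 60 nM to 10000 nM.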

Compound 3, half-maximal inhibitory concentration: 270 nM
Estimate against measurement, compound 3: 3.0-fold (0.47 log units) above; measured number inside the range.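

The amide-type nitrogen in the ring is a place where a single change can move the result in this assay: 4-methylbenzyl in place of 4-methoxyphenyl gives an at least 37-fold lower number from compound 2 to compound 3 (1.56 log units; beyond the scatter). The two groups have the same count of heavy atoms and each holds one six-membered aromatic ring of carbon only, so a matching heavy-atom count does not by itself keep the value in place. The printed step gives only the smallest possible size, and the full size cannot be read because compound 2 has a limit and not a number: the limit of > 10000 nM in this assay, at which 2 of the 3 values shown sit.

On these data alone, whether the benzyl form or the loss of the methoxy oxygen matters more stays open, as the two change together in this one step. As far as these compounds go, how 4-methoxybenzyl, plain benzyl or a longer chain ending in an amine would behave on this nitrogen also stays open.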